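The source may report more compounds than this note shows. Statements on the series, on what has been measured and on what is new or still open speak of the compounds shown alone.

Measured compounds:
compound 1 `Brc1cn2ccnc2c(-c2ccc3ncn(C4CCCCC4)c3c2)n1`: 15.8%
compound 2 `COc1ccc(-c2cn3ccnc3c(-c3ccc4ncn(C5CCCCC5)c4c3)n2)cc1`: -26.5%
compound 3 `O=Cc1ccc(-c2cn3ccnc3c(-c3ccc4ncn(C5CCCCC5)c4c3)n2)cc1`: 23.7%

In a functional assay on OVCAR-3 cells (Homo sapiens) for inhibition, read by sulforhodamine B assay, with a stated time of 48 h, tested at 10 uM (a higher number here means more inhibition at the concentration tested (going by the name of the read-out), a lower number less inhibition), compound 1 gives 15.8%, the second highest of the three numbers. Compound 3 stands nearest, with a step of a number 7.9 percentage points higher from compound 1 to compound 3 (within the scatter), which is within the scatter. Compound 2 stands furthest, with a step of a number 42.3 percentage points lower from compound 1 to compound 2 (beyond the scatter), a large fall.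

Compound 4 `c1ccc2c(-c3cn4ccnc4c(-c4ccc5ncn(C6CCCCC6)c5c4)n3)cccc2c1` is the new compound. Its change from compound 1 is naphthalen-1-yl in place of bromo on an aromatic carbon. Going by the values given here, two measured steps bear on it, since both also put a ring-containing group in place of bromo: the step of a number 42.3 percentage points lower from compound 1 to compound 2 (beyond the scatter) was large and downward, whereas the step of a number 7.9 percentage points higher from compound 1 to compound 3 (within the scatter) stayed within the scatter. So replacing bromo with a ring-containing group has once cost much and once cost nothing, and the new group shares with bromo the absence of hydrogen-bond donors and acceptors. The expectation therefore lies between those two outcomes, with a wide range. Compound 4 is expected to give 2%, between -35% and 35%. The expected step is a number 13.8 percentage points lower from compound 1 to compound 4 (beyond the scatter).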

Compound 4, a percentage reported as inhibition, at one concentration (the size of the read-out at that concentration, not a potency): 2.38%
Beside the measured number, compound 4's estimate is 0.4 percentage points below it; the range from low to high includes it.
By their numbers in this assay, from the lowest: compound 2; then compound 4; then compounds 1 and 3 (each within the scatter of the next).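

In this assay, naphthalen-1-yl, with its two aromatic rings of carbon only, gives a third kind of outcome at this position: a drop of modest size, with a number 13.4 percentage points lower from compound 1 to compound 4 (beyond the scatter) and a number 21.3 percentage points lower from compound 3 to compound 4 (beyond the scatter). It still sits clear of the methoxy-bearing compound, with a number 28.9 percentage points higher from compound 2 to compound 4 (beyond the scatter), so among these three ring-bearing replacements of bromo the group with two rings does not give the lowest number. Nothing available here explains these differences.

Going by these compounds, it remains open whether a group with no ring, such as a longer alkyl chain, would hold the number near that of bromo. On these data alone, it is also open how an amine or a carboxylic acid in place of formyl on the phenyl ring would change the result.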